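Methoxy for methyl on an aromatic carbon

The source may report more compounds than this note shows. Statements on the series, on what has been measured and on what is new or still open speak of the compounds shown alone.

In a functional assay on DU-145 cells (Homo sapiens) for inhibition, read by MTT assay, with a stated time of 72 h (on this read-out lower numbers stand for stronger inhibition and higher numbers for weaker inhibition), compound 1 `O=C1C=C(N2CCN(c3ccc(F)cc3)CC2)C(=O)c2ccccc21` gives 11700 nM and compound 2 `Cc1cccc(N2CCN(C3=CC(=O)c4ccccc4C3=O)CC2)c1` gives 7400 nM. These two numbers lie within the usual scatter of each other, so neither compound can be called the better one. Compound 3 `COc1cccc(N2CCN(C3=CC(=O)c4ccccc4C3=O)CC2)c1` has not yet been measured. It keeps the core of compound 2 and differs in one group: methoxy in place of methyl on an aromatic carbon. This is methoxy in place of methyl on an aromatic carbon, meta to a large group. Going by the values given here, only one measured step bears on this change, a 1.6-fold lower number from compound 1 to compound 2 (0.20 log units; within the scatter), which also alters the group on the phenyl ring, though with a different swap. With so little evidence, no step beyond the scatter is expected in this assay. The estimate amounts to an expected 1.1-fold higher number from compound 2 to compound 3 (0.03 log units; within the scatter). Compound 3 is expected to give about 8000 nM, with an estimated range of 3500 nM to 18000 nM.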

Compound 3, half-maximal inhibitory concentration: 15000 nM
Compound 3: the middle estimate sits 1.9-fold (0.27 log units) below what was measured; the measured number falls inside the stated range.
By their numbers in this assay, from the lowest: compounds 2, 1 and 3 (each within the scatter of the next, the first and the last beyond it).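

Going by these compounds alone, on this ring carbon, methoxy and methyl are not interchangeable in this assay: the swap gives a 2.0-fold higher number from compound 2 to compound 3 (0.31 log units; beyond the scatter) and is the first step in this small set to pass beyond the scatter, though only modestly. The other new comparison, a 1.3-fold higher number from compound 1 to compound 3 (0.11 log units; within the scatter), stays within the scatter, so the 3-methoxyphenyl and 4-fluorophenyl groups cannot be ranked against each other. No measurement here accounts for the difference between methyl and methoxy.

A single pair cannot show whether the trend follows the size of the group or something else about methoxy. A hydroxyl, an ethoxy or an amine on the same carbon would test this, and methyl and methoxy on other carbons of the ring would show whether the step is tied to this place.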